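Notes on the step from compound 2 to compound 3

A few compounds are considered here, and "the series" means these few. Any claim that something is new, unique, unknown or untested is made for them only; others in the source may bear on it.

In a functional assay on MCF7 cells (Homo sapiens) for inhibition, read by resazurin assay, with a stated time of 24 h (a higher number here means a weaker inhibitor, a lower number a stronger inhibitor), compound 1 (`O=C1Nc2c(C(F)(F)F)cccc2C1(c1ccc(OC(F)(F)F)cc1)c1cc(F)c(O)c(F)c1`) gives > 1000 nM as a limit and not a number.

Within the data shown here, compound 2 (`O=C1Nc2c(C(F)(F)F)cccc2C1(c1ccc(OC(F)(F)F)cc1)c1c(F)cc(O)cc1F`) gives 549 nM in this assay and holds the only exact number so far.

Compound 3 (`O=C1Nc2c(C(F)(F)F)cccc2C1(c1ccc(OC(F)(F)F)cc1)c1ccc(O)c(O)c1`) carries 3,4-dihydroxyphenyl in place of 2,6-difluoro-4-hydroxyphenyl on a saturated ring carbon and is still unmeasured.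

Among the measured compounds shown here, the one measured step at this same carbon is an at least 1.8-fold lower number from compound 1 to compound 2 (0.26 log units; that floor lies within the scatter) and is only a floor within the scatter, so no step beyond the scatter is expected.

The estimated step is a 1.3-fold higher number from compound 2 to compound 3 (0.11 log units; within the scatter) and no more than that is expected.

For compound 3 the estimate is 700 nM with an expected range from 220 nM to 2200 nM as a working figure.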

Compound 3, half-maximal inhibitory concentration: 49 nM
Compound 3: middle estimate off by 14-fold (1.15 log units), on the high side; measured number outside the range, below it.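

In this assay, the saturated ring carbon now shows a step beyond the scatter: 3,4-dihydroxyphenyl brings an 11-fold lower number from compound 2 to compound 3 (1.05 log units; beyond the scatter) and no fluorine remains on that ring. Against 3,5-difluoro-4-hydroxyphenyl, the same group brings an at least 20-fold lower number from compound 1 to compound 3 (1.30 log units; beyond the scatter), and that figure is only a floor: the limit of > 1000 nM in this assay, at which 1 of the 3 values shown sits.

The step removes two fluorines and adds a hydroxyl at once, so the compounds shown do not separate these two changes. Also open, going by these compounds, is whether a methoxy group or an amine could stand in place of either hydroxyl on this ring.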